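The source may report more compounds than this note shows. Statements on the series, on what has been measured and on what is new or still open speak of the compounds shown alone.

Measured so far in a functional assay on A549 cells (Homo sapiens) for cytotoxicity, read by MTT assay, with a stated time of 72 h; a lower number here means a stronger inhibitor, a higher number a weaker inhibitor:

- compound 1 `O=C1c2c[n+]([O-])c3ccccc3c2C(=O)c2c1c1ccccc1n2Cc1cn([C@H]2O[C@H](CO)[C@@H](O)[C@H]2O)nn1` gives 2680 nM
- compound 2 `O=C1c2c[n+]([O-])c3ccccc3c2C(=O)c2c1c1ccccc1n2Cc1cn([C@@H]2C[C@H](O)[C@@H](CO)O2)nn1` gives 120 nM
- compound 3 `O=C1c2c[n+]([O-])c3ccccc3c2C(=O)c2c1c1ccccc1n2CCN1CCCC1` gives 410 nM

Compound 3 holds the middle place of these three numbers. Its value lies above that of compound 2 and below that of compound 1, and both gaps are beyond the scatter. Compound 4 `CN1CCN(CCCn2c3c(c4ccccc42)C(=O)c2c[n+]([O-])c4ccccc4c2C3=O)CC1` has not yet been measured. It differs from compound 3 as follows: (4-methylpiperazin-1-yl)methyl in place of pyrrolidin-1-yl on a saturated chain carbon, two bonds along the chain from an aromatic nitrogen. In words, (4-methylpiperazin-1-yl)methyl stands in place of pyrrolidin-1-yl on a saturated chain carbon, two bonds along the chain from an aromatic nitrogen, which turns 2-(pyrrolidin-1-yl)ethyl into 3-(4-methylpiperazin-1-yl)propyl.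

Within the data shown here, only one measured step exists, a 22-fold lower number from compound 1 to compound 2 (1.35 log units; beyond the scatter). It is large, but it changes another part of the molecule and involves no swap of one amine chain for another, so it gives no direction for this change. It shows only that edits outside the shared core can move the number widely in this assay. Among the measured compounds shown here, with no closer precedent, the value of compound 3, 410 nM, remains the best anchor, and no step beyond the scatter is confidently expected. The expected step is a 1.2-fold lower number from compound 3 to compound 4 (0.07 log units; within the scatter), with a wide margin either way. For compound 4 the estimated value is 350 nM, within an expected range of 110 nM to 1100 nM.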

Compound 4, half-maximal inhibitory concentration: 140 nM
Compound 4: the middle estimate sits 2.5-fold (0.40 log units) above what was measured; the measured number falls inside the stated range.
By their numbers in this assay, from the lowest: compounds 2 and 4 (each within the scatter of the next); then compound 3; then compound 1.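

In this assay, among these compounds, the edit at this saturated chain carbon, two bonds along the chain from an aromatic nitrogen, gives a 2.9-fold lower number from compound 3 to compound 4 (0.47 log units; beyond the scatter), the first reading of one amine chain against another, since the earlier step concerned a hydroxy on a saturated ring carbon. The step shows that the number responds to the amine chain and that 3-(4-methylpiperazin-1-yl)propyl gives a lower number than 2-(pyrrolidin-1-yl)ethyl, although this one pair sets no trend. No measurement bears on why the number falls with this change.

As far as these compounds go, the edit alters the ring and the chain length together, so it remains open how much of the step belongs to the six-membered ring with 2 hetero atoms and how much to the longer chain; a 2-(4-methylpiperazin-1-yl)ethyl or a 3-(pyrrolidin-1-yl)propyl chain would separate the two. Also open, from the compounds shown here alone, is how far the trend would run with a morpholine ring, a dimethylamino group or a still longer butyl chain carrying the 4-methylpiperazin-1-yl group.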